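Replacing ethyl(isopropyl)amino with dimethylamino on a sulfonamide

The source may hold more compounds than are shown below. What is called first, only, known or untested is meant among the compounds shown, and "the series" means these compounds.

Measured so far:
- compound 1, `CCOC(=O)[C@@H]1CCC[C@H](S(=O)(=O)c2ccc(S(=O)(=O)N(CC)CC)cc2)C1`: > 10000 nM in a functional assay on MIA PaCa-2 cells (Homo sapiens) for inhibition, read by MTT assay, with a stated time of 3 days; a lower number here means a stronger inhibitor, a higher number a weaker inhibitor
- compound 2, `CCOC(=O)[C@@H]1CCCN(S(=O)(=O)c2ccc(S(=O)(=O)N(CC)C(C)C)cc2)C1`: > 10000 nM
- compound 3, `CCN(CC)S(=O)(=O)c1ccc(S(=O)(=O)N2CCC[C@@H](c3cc(C)no3)C2)cc1`: > 10000 nM

Each of these three values is a limit of this assay rather than a measured number. For compound 2 the reading of > 10000 nM therefore says only that any inhibition lies beyond what the test can resolve. For the measured compounds named here, the same holds for compound 1 and compound 3, as the limit of > 10000 nM in this assay, at which 3 of the 3 values shown sit, makes clear: every value shown so far sits at that limit, so no step between measured compounds can be sized.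

The next compound keeps the whole core of compound 2 and alters only the amine on the second sulfonyl group. Compound 4, `CCOC(=O)[C@@H]1CCCN(S(=O)(=O)c2ccc(S(=O)(=O)N(C)C)cc2)C1`, differs from compound 2 in this way: dimethylamino in place of ethyl(isopropyl)amino on a sulfonyl sulfur. Going by the values given here, nothing among the compounds so far shows whether shrinking that amine moves activity in this assay at all, because all three sit at the limit (the limit of > 10000 nM in this assay, at which 3 of the 3 values shown sit).

Among the compounds with values here, with no measured step to lean on, the expected change from compound 2 to compound 4 is a number no higher from compound 2 to compound 4 (the limit leaves the size open), which is to say none beyond the scatter. Compound 4 is therefore expected to give about 10000 nM, within a range from 3000 nM to 30000 nM, most likely again reported only as a limit.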

Compound 4, half-maximal inhibitory concentration: > 10000 nM
Compound 4: a limit, no number (the forecaster's own chance of this, stated with the estimate: 80%); the middle value lies on the limit itself.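

Compound 4 gives > 10000 nM in this assay and that reading is a limit, not a number. For the compounds shown here, compound 2 also stands at a limit, so no step between the two can be read: the limit of > 10000 nM in this assay, at which 4 of the 4 values shown sit. The compounds shown leave open how strongly, if at all, any of them inhibits in this assay.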